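The source may report more compounds than this note shows. Statements on the series, on what has been measured and on what is new or still open speak of the compounds shown alone.

Measured compounds:
compound 1 `N#Cc1cccc(C(=O)NC(=S)N2CCc3c(OCCCCCOc4ccc(Cl)cc4)cccc32)c1` — 9750 nM
compound 2 `O=C(NC(=S)N1CCc2c(OCCCCCOc3ccc(Cl)cc3)cccc21)c1ccc(Br)cc1` — 29100 nM

In an ADME assay on Huh-7 cells (Homo sapiens) for cytotoxicity (a higher number here means that more compound is tolerated, a lower number that less compound is tolerated), compound 2 gives the highest of the two numbers; its nearest neighbour is compound 1, and the one measured step, a 3.0-fold higher number from compound 1 to compound 2 (0.47 log units; beyond the scatter), is the only comparison shown. Compound 3 `Cc1ccc(C(=O)NC(=S)N2CCc3c(OCCCCCOc4ccc(Cl)cc4)cccc32)cc1` differs from compound 2 by methyl in place of bromo on an aromatic carbon. Among the compounds with values here, no measured step exchanges bromo for methyl, and the step from compound 1 to compound 2 swapped a whole aryl group rather than one substituent, so it bears only loosely. The expected step of a 1.2-fold lower number from compound 2 to compound 3 (0.07 log units; within the scatter) is therefore small, likely within the scatter. Compound 3 is estimated at 25000 nM, between 10000 nM and 60000 nM.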

Compound 3, half-maximal cytotoxic concentration: > 50000 nM
Compound 3: only a limit was reported; the forecaster's own chance of this, stated with the estimate: 10%; middle value at least 2.0-fold (0.30 log units) away from the limit.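

In this assay compound 3 gives > 50000 nM, which is a limit and not a number: the limit of > 50000 nM in this assay, at which 1 of the 3 values shown sits.
Putting methyl in place of bromo gives an at least 1.7-fold higher number from compound 2 to compound 3 (0.23 log units; that floor lies within the scatter), so no real difference between these two para groups is shown. The 4-methylphenyl group still stands clearly apart from 3-cyanophenyl, with an at least 5.1-fold higher number from compound 1 to compound 3 (0.70 log units; beyond the scatter), so bromine is not needed for this gap.

From the compounds shown here alone, the true number for compound 3 stays open. So does whether an amine or a carboxylic acid at this position would be tolerated as well, or whether methyl would behave the same on a 3-methylphenyl group.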